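A few compounds are considered here, and "the series" means these few. Any claim that something is new, unique, unknown or untested is made for them only; others in the source may bear on it.

Of the compounds shown here, three from one series have been tested in an ADME assay on RAW264.7 cells (Mus musculus) for cytotoxicity, read by MTT assay, with a stated time of 24 h, tested at 5 ug/mL; a higher number here means a weaker effect of the compound at the concentration tested, a lower number a stronger effect. Compound 1 `COc1ccc(C(=O)/C=C/c2ccc(OC)c(OC)c2OC)c(O)c1` gives 72.5% in this assay. Compound 2 `COc1ccc(C(=O)/C=C/c2cccc(OC)c2OC)c(O)c1`, which carries one methoxy group fewer on its ring, gives 69.7% in this assay. Compound 3 `COc1ccc(C(=O)CCc2ccc(OC)c(OC)c2)c(O)c1` gives 75.2% in this assay, the highest of the three numbers, though its distances to compound 1 and to compound 2 both lie within the usual scatter. How the core of compound 3 differs from the core of compound 2 is not broken down here.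

One structural change has already been observed between measured compounds: from compound 2 to compound 1 the change is methoxy in place of hydrogen on an aromatic carbon. That step, a number 2.8 percentage points higher from compound 2 to compound 1 (within the scatter), stays within the scatter.

Compound 4 `COc1ccc(C(=O)CCc2ccc(OC)c(OC)c2OC)c(O)c1` has not yet been tested. It differs from compound 3 by methoxy in place of hydrogen on an aromatic carbon. Going by the values given here, this is the same kind of change as the one from compound 2 to compound 1, but not the same: in compound 1 the entering methoxy group sits para to a large group, whereas in compound 4 it sits ortho to a large group.

Among the compounds with values here, the expectation for compound 4 rests on the single measured step of this kind, because a number 2.8 percentage points higher from compound 2 to compound 1 (within the scatter) was small. The step is therefore expected to be a number 1.8 percentage points higher from compound 3 to compound 4 (within the scatter), also within the scatter. The estimate for compound 4 in this assay is 77%, with a range from 68% to 86%.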

Compound 4, a percentage reported as activity, at one concentration (the size of the read-out at that concentration, not a potency): 94.8%
Compound 4: middle estimate off by 17.8 percentage points, on the low side; the measured number lies above the stated range.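

In this assay, the same swap of hydrogen for methoxy on an aromatic carbon gives a number 19.6 percentage points higher from compound 3 to compound 4 (beyond the scatter), which means a clearly weaker effect at the concentration tested, and the size of this step did not carry over from one core to the other: the same change on two cores in this assay, a number 2.8 percentage points higher (within the scatter) from compound 2 to compound 1 and a number 19.6 percentage points higher (beyond the scatter) from compound 3 to compound 4, 16.8 percentage points apart, beyond the scatter of two such steps. A step measured on one core of this series is therefore a poor guide to the size of the same change on another core. The result does not show what sets the size of the step, since the two pairs differ both in their cores and in the place where the methoxy group enters, which in compound 4 is ortho to a large group and ortho to a methoxy group, and two steps are too few to support a rule for the series.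

The compounds shown leave open whether the large step belongs to methoxy itself or would appear with other groups at the same place, such as an ethoxy group, an amine or a carboxylic acid. They also leave open what the same methoxy group would do at this place on the core of compound 2.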